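A few compounds are considered here, and "the series" means these few. Any claim that something is new, unique, unknown or untested is made for them only; others in the source may bear on it.

Compound 2 `O=C(COc1ccc(Oc2ccccc2)cc1)Cn1ncc2cc(NC(=O)CO)ccc21` has the lower of two numbers in an assay on microsomes from brain for inhibition of Fatty-acid amide hydrolase 1 (Rattus norvegicus), read by fluorescence and HPLC, with a stated time of 45 min (on this read-out lower numbers stand for stronger inhibition and higher numbers for weaker inhibition), where compound 2 gives 5400 nM. For the measured compounds named here, its only neighbour with a measurement is compound 1 `COCC(=O)Nc1ccc2c(cnn2CC(=O)COc2ccc(Oc3ccccc3)cc2)c1`, which in this assay gives 6300 nM; the step of a 1.2-fold lower number from compound 1 to compound 2 (0.07 log units; within the scatter) is small, so the two compounds are not distinguished by this assay.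

Compound 3 `COC(=O)Nc1ccc2c(cnn2CC(=O)COc2ccc(Oc3ccccc3)cc2)c1` differs from compound 2 by a change at the amide end of the shared core: methoxy in place of hydroxymethyl on a carbonyl carbon. Going by the values given here, no measured pair shows exactly this change. Among the compounds with values here, the only step available, a 1.2-fold lower number from compound 1 to compound 2 (0.07 log units; within the scatter), alters the same region and stays inside the scatter, which suggests that changes at this end of the molecule have had little influence on this assay so far. The expected step of a 1.1-fold lower number from compound 2 to compound 3 (0.03 log units; within the scatter) is therefore estimated to be none beyond the scatter. In this assay compound 3 is expected to give about 5000 nM, with a likely range from 1500 nM to 16000 nM.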

Compound 3, half-maximal inhibitory concentration: 4000 nM
Compound 3: middle estimate off by 1.3-fold (0.10 log units), on the high side; the range from low to high includes it.
By their numbers in this assay, from the lowest: compounds 3, 2 and 1 (each within the scatter of the next).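

In this assay the swap of hydroxymethyl for methoxy on the carbonyl carbon gives a 1.4-fold lower number from compound 2 to compound 3 (0.13 log units; within the scatter) and the swap of methoxymethyl for methoxy gives a 1.6-fold lower number from compound 1 to compound 3 (0.20 log units; within the scatter), so both steps stay within the scatter. Together with the earlier step, this means the assay does not tell the three groups apart, even though hydroxymethyl counts 1 hydrogen-bond donor and methoxy 0, and the atom joined to the carbonyl carbon is carbon in two of the groups and oxygen in the third. No measurement on hand offers an explanation for this result.

Going by these compounds, all three groups carry no net charge, so it remains open whether an amine or a carboxylic acid on this carbonyl carbon would shift the number beyond the scatter. The same question stands for a longer chain there, such as butoxy.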